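The compounds below may be only part of what the source reports. "The series", "measured", "known", "first", "only" and "open" are said of these compounds alone.

Measured so far:
Compound 1, `CCCCCn1ccc2cc(/C(C)=C/C(=O)Nc3ccccc3OCCCC(=O)O)ccc21` — in an assay on Prostate gland for inhibition of steroid 5-alpha-reductase (Rattus norvegicus) (on this read-out lower numbers stand for stronger inhibition and higher numbers for weaker inhibition), compound 1 gives 23 nM.
Compound 2, `CCCCCCCn1ccc2cc(/C(C)=C/C(=O)Nc3ccccc3OCCCC(=O)O)ccc21` — in this assay compound 2 gives 120 nM.

Among the measured compounds shown here, compound 2 stands at the higher of the two numbers, meaning the weaker inhibition; the only measured step, a 5.2-fold higher number from compound 1 to compound 2 (0.72 log units; beyond the scatter), runs from the pentyl chain of compound 1 to the longer heptyl chain of compound 2.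

Compound 3, `CCCCC(C)n1ccc2cc(/C(C)=C/C(=O)Nc3ccccc3OCCCC(=O)O)ccc21`, is not yet measured. Compared with compound 2 it carries 1-methylpentyl in place of heptyl on an aromatic nitrogen: the chain on the ring nitrogen becomes one carbon shorter and gains a branch at its first carbon.

The step that bears on this is a 5.2-fold higher number from compound 1 to compound 2 (0.72 log units; beyond the scatter), which shows that lengthening the chain raised the number. Shortening it again by one carbon should partly reverse that, while the branch is untested; compound 3 is therefore expected to land between the two measured values, with a 2.7-fold lower number from compound 2 to compound 3 (0.43 log units; beyond the scatter) as the expected step.

For compound 3 the estimate in this assay is 45 nM, within the range 15 nM to 130 nM.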

Compound 3, half-maximal inhibitory concentration: 6 nM
Compound 3: the middle estimate sits 7.5-fold (0.88 log units) above what was measured, outside the stated range (below it).
By their numbers in this assay, from the lowest: compound 3; then compound 1; then compound 2.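

Among the compounds shown here, until now the only change on the aromatic nitrogen was a longer chain, which weakened inhibition; a branch at the first chain carbon now does the opposite. In this assay the change from heptyl to 1-methylpentyl brings a 20-fold lower number from compound 2 to compound 3 (1.30 log units; beyond the scatter) and, more tellingly, adding only the methyl to the pentyl chain brings a 3.8-fold lower number from compound 1 to compound 3 (0.58 log units; beyond the scatter) so the branch itself strengthens inhibition, not merely a shorter chain. Nothing available here explains why this branch has that effect.

The compounds shown leave open whether a longer branched chain such as 1-methylheptyl, or a second methyl on that first carbon as in 1,1-dimethylpentyl, would lower the number further. They also leave open whether a ring such as cyclohexyl on the nitrogen would match the open branched chain.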